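The source may report more compounds than this note shows. Statements on the series, on what has been measured and on what is new or still open speak of the compounds shown alone.

Measured compounds in the series:
compound 1 `CNC(=O)c1cccn(Cc2ccccc2)c1=O`, 3
compound 2 `CCNC(=O)c1cccn(Cc2ccccc2)c1=O`, 3.7
compound 3 `CNC(=O)c1cc(C(=O)NC2CC2)cn(CC2CCCOC2)c1=O`, 2

In a physicochemical assay for lipophilicity, at pH 7.4 (on this read-out higher numbers stand for higher lipophilicity and lower numbers for lower lipophilicity), compound 1 stands second highest of the three numbers. Its nearest neighbour is compound 2, with the step of a number 0.70 log units higher from compound 1 to compound 2 (beyond the scatter); furthest is compound 3, which gives 2, while compound 1 gives 3, a gap beyond the scatter, but compound 3 differs from compound 1 in more than one place, so no single step is shown for that pair.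

Compound 4 `CNC(=O)c1cc(C(=O)NCCOC)cn(Cc2ccccc2)c1=O` is not yet measured in this assay. Its change from compound 1: (2-methoxyethyl)carbamoyl in place of hydrogen on an aromatic carbon. No measured step adds a (2-methoxyethyl)carbamoyl group on an aromatic carbon; the single shown step, a number 0.70 log units higher from compound 1 to compound 2 (beyond the scatter), concerns a different place and a different group, so it bears on the expectation only as a gauge of how far one change can move this assay. Compound 3 carries a carbamoyl substituent at a comparable place and sits lowest, but its second change blocks a direct reading. The expected step is therefore downward, beyond the scatter, a number 0.70 log units lower from compound 1 to compound 4 (beyond the scatter). Compound 4 is estimated at 2.3, range 1.7 to 2.9.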

Compound 4, distribution coefficient: 2.7
The estimate for compound 4 lay 0.40 log units below the measured number, and the stated range covers the measured number.
By their numbers in this assay, from the lowest: compound 3; then compounds 4 and 1 (each within the scatter of the next); then compound 2.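

Adding (2-methoxyethyl)carbamoyl on the aromatic carbon two atoms from the ring nitrogen gives the first reading of this position with nothing else changed: in this assay the step is a number 0.30 log units lower from compound 1 to compound 4 (within the scatter). For the compounds shown here, a group of 7 heavy atoms can therefore enter here on the core of compound 1 without a step beyond the scatter, whereas the one earlier step, a number 0.70 log units higher from compound 1 to compound 2 (beyond the scatter), came from a single methyl in place of hydrogen on a saturated chain carbon bound to an amide-type nitrogen. No measured evidence bears on the reason for this result.

The compounds shown leave open whether a carboxylic acid, an aminomethyl group or a longer ether chain at this place would also stay within the scatter of compound 1. They also leave open whether (2-methoxyethyl)carbamoyl reads the same on a core without the benzyl group.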